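Series notes: aryl swap on the amide-type nitrogen

This account rests on a few compounds, and the source may have more. Where it says the series, first, only, none or still open, it means among the compounds named here.

Compound 2 `S=C(N/N=C/c1ccc2ccccc2n1)Nc1cccc(Br)c1` in a functional assay on HeLa cells (Homo sapiens) for antiproliferative activity, read by sulforhodamine B assay, with a stated time of 72 h (a lower number here means a stronger inhibitor, a higher number a weaker inhibitor), gives 70000 nM, the second highest of the three numbers. Compound 1 `Fc1cccc(NC(=S)N/N=C/c2ccc3ccccc3n2)c1` gives 70100 nM and compound 3 `CN(C)C(=S)N/N=C/c1cc2cccnc2s1` gives 48400 nM, both within the scatter of compound 2. Among the measured compounds shown here, the one measured step, a 1.0-fold lower number from compound 1 to compound 2 (0.00 log units; within the scatter), shows that swapping one substituent on the phenyl ring left the number flat. Compound 4 `COc1ccccc1NC(=S)N/N=C/c1ccc2ccccc2n1` carries 2-methoxyphenyl in place of 3-bromophenyl on an amide-type nitrogen. For the measured compounds named here, no measured step covers a methoxyphenyl group, so a 1.0-fold lower number from compound 1 to compound 2 (0.00 log units; within the scatter) bears on it only indirectly, arguing that a small change on this ring has not moved the number so far. The expected step is no change at the digits printed from compound 2 to compound 4 (within the scatter), none beyond the scatter. The estimate for compound 4 is 70000 nM, with a range of 35000 nM to 140000 nM.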

Compound 4, half-maximal inhibitory concentration: > 100000 nM
Compound 4: only a limit was reported; the forecaster's own chance of this, stated with the estimate: 10%; middle value at least 1.4-fold (0.15 log units) from the limit.
By their numbers in this assay, from the lowest: compounds 3, 2 and 1 (each within the scatter of the next). At a limit, above all of these: compound 4.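

At the amide-type nitrogen, 2-methoxyphenyl gives the first aryl result without a measured number: compound 4 has only a limit in this assay, > 100000 nM. The steps are an at least 1.4-fold higher number from compound 2 to compound 4 (0.15 log units; that floor lies within the scatter) and an at least 1.4-fold higher number from compound 1 to compound 4 (0.15 log units; that floor lies within the scatter), so this swap is not shown to move the number beyond the scatter. The result therefore marks a ceiling on the reading, not a size of effect: the limit of > 100000 nM in this assay, at which 1 of the 4 values shown sits.

As far as these compounds go, how far compound 4 lies past that limit stays open. Also open, from the compounds shown here alone, is whether an amine or a carboxylic acid on the phenyl ring would give a number beyond the scatter of compound 2.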